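A few compounds are considered here, and "the series" means these few. Any claim that something is new, unique, unknown or untested is made for them only; others in the source may bear on it.

Compound 1 `ClCc1cccc(Cn2cnc3ncnc(Cl)c32)c1`, compound 2 `ClCc1cccc(Cn2cnc3c(Cl)ncnc32)c1` and compound 3 `ClCc1cccc(Cn2cnc3c(Cl)nc(Cl)nc32)c1` share a chlorine-bearing benzyl arm attached to a fused two-ring core, and all three were tested in a functional assay on NCI-H226 cells (Homo sapiens) for cytotoxicity, read by sulforhodamine B assay, with a stated time of 48 h; a higher number here means a weaker inhibitor of growth, a lower number a stronger inhibitor of growth. Compound 1 gives 8700 nM, compound 2 gives 14400 nM and compound 3 gives 10000 nM, so all three sit close together and none can be set apart from the others. The cores of compound 1 and compound 2 are built from the same atoms joined differently, and that difference between the two cores is not broken down here.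

From compound 2 to compound 3 one change is made: chloro in place of hydrogen on an aromatic carbon. In this assay this gave a 1.4-fold lower number from compound 2 to compound 3 (0.16 log units; within the scatter), a step too small to count as a real shift.

Compound 4 `ClCc1cccc(Cn2cnc3nc(Cl)nc(Cl)c32)c1` has not yet been measured. It differs from compound 1 by chloro in place of hydrogen on an aromatic carbon, the same change as that from compound 2 to compound 3, placed in the same surroundings. If the change behaves as it did before, compound 4 is expected to show a 1.3-fold lower number from compound 1 to compound 4 (0.11 log units; within the scatter) in this assay, resting on the fact that the matching step from compound 2 to compound 3 stayed inside the scatter. Compound 4 is therefore estimated at 6800 nM, with a likely range from 3200 nM to 15000 nM.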

Compound 4, concentration for total growth inhibition: 3630 nM
Compound 4: the middle estimate sits 1.9-fold (0.27 log units) above what was measured; measured number inside the range.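

In this assay, chloro in place of hydrogen on an aromatic carbon, here between two ring nitrogen atoms, gave a 2.4-fold lower number from compound 1 to compound 4 (0.38 log units; beyond the scatter), a modest step that lies beyond the usual scatter of repeated measurements, whereas the earlier step stayed inside it. Set side by side, the two steps cannot be told apart: the same change on two cores in this assay, a 1.4-fold lower number (0.16 log units; within the scatter) from compound 2 to compound 3 and a 2.4-fold lower number (0.38 log units; beyond the scatter) from compound 1 to compound 4, 1.7-fold (0.22 log units) apart, within the scatter of two such steps. So one shared effect of this change on both cores fits the data, but this does not show that the core of compound 1 responds more strongly than the core of compound 2, it gives no reason for either step, and two pairs of compounds cannot set a rule for any other core.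

Every compound shown has either hydrogen or chloro at this place, so it remains open how a different group there, such as an amine or a methoxy group, would read in this assay. The chlorine-bearing benzyl arm is also the same throughout, which leaves open what would happen if its chlorine gave way to a hydroxyl group or if the arm became a longer chain.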